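The source may report more compounds than this note shows. Statements on the series, on what has been measured and on what is new or still open speak of the compounds shown alone.

Measured compounds:

Compound 1, `Cc1nn(Cc2ccccc2C(N)=O)c(C)c1NC(=O)c1ccc(COc2ccccc2)cc1`; in a functional assay on MIA PaCa-2 cells (Homo sapiens) for antiproliferative activity, read by MTT assay, with a stated time of 72 h (a higher number here means that more compound is needed for the effect, a lower number that less compound is needed), compound 1 gives 42000 nM.
Compound 2, `Cc1nn(Cc2cccc(C(=O)NC(C)C)c2)c(C)c1NC(=O)c1ccc(COc2ccccc2)cc1`; in this assay compound 2 gives 8900 nM.
Compound 3, `CNC(=O)c1cccc(Cn2nc(C)c(NC(=O)c3ccc(COC4CCCCC4)cc3)c2C)c1`; in this assay compound 3 gives 14000 nM.

Among these three numbers compound 3 stands second highest. Its nearest neighbour is compound 2, whose number lies within the usual scatter of it, and its furthest is compound 1, whose number is higher by more than the scatter.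

Compound 4, `CNC(=O)c1cccc(Cn2nc(C)c(NC(=O)c3ccc(COc4cccc(C)c4)cc3)c2C)c1`, has not yet been measured. It differs from compound 3 in one place: 3-methylphenyl in place of cyclohexyl on an oxygen on a saturated carbon. For the measured compounds named here, no measured step touches this part of the molecule. Going by the values given here, the only measured step, a 4.7-fold lower number from compound 1 to compound 2 (0.67 log units; beyond the scatter), concerns the group on the saturated chain carbon bound to the aromatic nitrogen, a different place altogether. Compounds 2 and 3 differ in two places at once, and their two values lie within the scatter of each other, which gives no sign that the group on this oxygen shifts the number by much. The step from compound 3 to compound 4 is therefore expected to be small, a 1.3-fold lower number from compound 3 to compound 4 (0.10 log units; within the scatter), with no direction beyond the scatter. For compound 4 the estimate in this assay is 11000 nM, with a likely range from 4000 nM to 30000 nM.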

Compound 4, half-maximal effective concentration: 6200 nM
The estimate for compound 4 lay 1.8-fold (0.25 log units) above the measured number, within the range that was stated.
By their numbers in this assay, from the lowest: compounds 4, 2 and 3 (each within the scatter of the next, the first and the last beyond it); then compound 1.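

The group on this oxygen clearly affects the number: changing cyclohexyl to 3-methylphenyl gives a 2.3-fold lower number from compound 3 to compound 4 (0.35 log units; beyond the scatter) in this assay, a modest step that lies just beyond the usual scatter. For the compounds shown here, this is the first single change measured at this end of the molecule, as the earlier step concerned only the group on the saturated chain carbon bound to the aromatic nitrogen. No available evidence explains why this change lowers the number.

The change replaces a non-aromatic ring with an aromatic one and adds a methyl at the same time, so the compounds shown cannot say how much of the step belongs to each, and a plain phenyl alongside the same methylamide would separate them. Going by these compounds, it also remains open how a methoxy group or an amine in place of that methyl would alter the number.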